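Cyclohexyl for Phenyl on the Amide of Compound 2

The source may hold more compounds than are shown below. What is called first, only, known or untested is meant among the compounds shown, and "the series" means these compounds.

Compound 1 `CS(=O)(=O)Nc1ccc([N+](=O)[O-])cc1OCc1ccc([N+](=O)[O-])cc1`: 400 nM
Compound 2 `O=C(Nc1ccc([N+](=O)[O-])cc1OCc1ccccc1)c1ccccc1`: > 25000 nM

In an assay on SK-BR-3 cells for inhibition of Aromatase (Homo sapiens) (on this read-out lower numbers stand for stronger inhibition and higher numbers for weaker inhibition), compound 1 gives 400 nM. For compound 2 only a limit is known in this assay, > 25000 nM, not a number. Compound 2 thus stands at the limit of > 25000 nM in this assay, at which 1 of the 2 values shown sits. Compound 3 `O=C(Nc1ccc([N+](=O)[O-])cc1OCc1ccccc1)C1CCCCC1` is reached from it by cyclohexyl in place of phenyl on a carbonyl carbon. Among the measured compounds shown here, no pair of measured compounds differs in a single place, so no measured step gives a scale for this change. Compound 3 is expected to stay at the limit, the expected step being a step that the limit leaves unreadable from compound 2 to compound 3, nothing beyond the scatter. The estimate for compound 3 is 30000 nM, spanning 8000 nM to 100000 nM.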

Compound 3, half-maximal inhibitory concentration: > 25000 nM
Compound 3 ended at the assay's limit; the forecaster's own chance of this, stated with the estimate: 80%; the middle value lies beyond the limit too.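

Compound 2 and compound 3 each give only a limit, not a number, so no step between them can be read: the limit of > 25000 nM in this assay, at which 2 of the 3 values shown sit.

The compounds shown leave open whether cyclohexyl in place of phenyl on a carbonyl carbon changes inhibition at all.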